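Working notes: from compound 3 to compound 4

This account rests on a few compounds, and the source may have more. Where it says the series, first, only, none or still open, it means among the compounds named here.

Of the compounds shown here, three of one shared core have been measured. Compound 1 `Cc1nc(S(C)(=O)=O)ccc1Oc1ncnc(OC2CCN(C(=O)O[C@@H](C)C(F)(F)F)CC2)c1F` gives 80% in a functional assay on isolated protein for inhibition of Glucose-dependent insulinotropic receptor (Rattus norvegicus), read by HTRF and cAMP accumulation; a lower number here means a smaller maximal response, a higher number a larger maximal response. Compound 2 `Cc1nc(S(C)(=O)=O)ccc1Oc1ncnc(OC2CCN(C(=O)SC3CCC3)CC2)c1F` gives 81% in this assay; the step of a number 1 percentage points higher from compound 1 to compound 2 (within the scatter) lies within the scatter, so the two numbers are read as alike. Compound 3 `Cc1nc(S(C)(=O)=O)ccc1Oc1ncnc(OC2CCN(C(=S)OC3(C)CC3)CC2)c1F` gives 49% in this assay, the lowest of the three numbers; both steps leading to it, a number 31 percentage points lower from compound 1 to compound 3 (beyond the scatter) and a number 32 percentage points lower from compound 2 to compound 3 (beyond the scatter), lie beyond the scatter and are large.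

Compound 4 `Cc1nc(S(C)(=O)=O)ccc1Oc1ncnc(OC2CCN(C(=O)C(C)(F)F)CC2)c1F` is not yet measured. Its change from compound 3 is a group of 6 heavy atoms (3 carbon, 1 oxygen, 2 fluorine; no ring) in place of a group of 7 heavy atoms (5 carbon, 1 oxygen, 1 sulfur; one three-membered non-aromatic ring of carbon only), on an amine nitrogen in a ring. The entering group sits on a carbonyl, as do the groups of compound 1 and compound 2, whereas the leaving group carries the thiocarbonyl that only compound 3 has. The steps of a number 31 percentage points lower from compound 1 to compound 3 (beyond the scatter) and a number 32 percentage points lower from compound 2 to compound 3 (beyond the scatter) therefore bear on this change, and a step of similar size in the opposite direction is expected in this assay: a number 27 percentage points higher from compound 3 to compound 4 (beyond the scatter). The estimate for compound 4 is 76%, with a range from 60% to 92%. Among the measured compounds shown here, no measured compound carries the entering group, so the range is kept wide.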

Compound 4, largest response reached (reported as efficacy), in percent of the reference or control that the assay uses: 87%
The estimate for compound 4 lay 11 percentage points below the measured number; measured number inside the range.
By their numbers in this assay, from the lowest: compound 3; then compounds 1, 2 and 4 (each within the scatter of the next).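

The step of a number 38 percentage points higher from compound 3 to compound 4 (beyond the scatter) in this assay shows that a carbonyl on the amine nitrogen in the ring can carry 1,1-difluoroethyl, attached through carbon, and keep the high maximal response, so the linking oxygen of compound 1 and the linking sulfur of compound 2 are not needed for it. Among the compounds shown here, with a number 6 percentage points higher from compound 2 to compound 4 (within the scatter) and a number 7 percentage points higher from compound 1 to compound 4 (within the scatter), all three carbonyl compounds read alike, leaving compound 3, the only thiocarbonyl, as the one low number among the four compounds. No measurement at hand bears on what lies behind this step.

The compounds shown do not separate the thiocarbonyl of compound 3 from its three-membered ring of carbon only. From the compounds shown here alone, how the carbonyl series would read with a dimethylamino group or a longer chain such as pentyl also stays open.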